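Replacing the amine tail of compound 1 with a methyl ester chain

The source may hold more compounds than are shown below. What is called first, only, known or untested is meant among the compounds shown, and "the series" means these compounds.

Compound 1 `CCn1c(C(=O)NCCN)ccc1C(CC)(CC)c1ccc(OCCC(O)(CC)CC)c(C)c1` carries a 2-aminoethyl group on its amide nitrogen. For the measured compounds named here, in a functional assay on MCF7 cells (Homo sapiens) for antiproliferative activity, read by MTT assay, with a stated time of 48 h (on this read-out higher numbers stand for weaker inhibition and lower numbers for stronger inhibition), compound 1 gives 670 nM, the only outright number among the three values shown. Compound 2 `C=CCN(C)C(=O)c1ccc(C(CC)(CC)c2ccc(OCCC(O)(CC)CC)c(C)c2)n1CC` reaches only the limit of the assay, > 50000 nM. Compound 3 `CCn1c(C(=O)Nc2cccc(C(F)(F)F)c2)ccc1C(CC)(CC)c1ccc(OCCC(O)(CC)CC)c(C)c1` likewise reaches only a limit, > 50000 nM. Both measured steps away from compound 1 are large: an at least 74-fold higher number from compound 1 to compound 2 (1.87 log units; beyond the scatter) and an at least 74-fold higher number from compound 1 to compound 3 (1.87 log units; beyond the scatter). The two limits themselves make the step between compound 2 and compound 3 unreadable, a step that the two limits leave unreadable from compound 2 to compound 3, so it is worth noting only (the limit of > 50000 nM in this assay, at which 2 of the 3 values shown sit).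

Compound 4 `CCC(C)C(NC(=O)c1ccc(C(CC)(CC)c2ccc(OCCC(O)(CC)CC)c(C)c2)n1CC)C(=O)OC` differs from compound 1 in the same place as both measured steps: a group of 9 heavy atoms (7 carbon, 2 oxygen; no ring) in place of a group of 3 heavy atoms (2 carbon, 1 nitrogen; no ring), on an amide-type nitrogen. Both earlier changes at this amide nitrogen pushed the number past the limit, and the same outcome is expected here. The expected step is a 45-fold higher number from compound 1 to compound 4 (1.65 log units; beyond the scatter), a marked weakening. Compound 4 is therefore estimated to give about 30000 nM, with a range from 5000 nM to 100000 nM, and quite possibly only a limit.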

Compound 4, half-maximal inhibitory concentration: > 50000 nM
Compound 4 was reported as a limit; the forecaster's own chance of this, stated with the estimate: 60%; middle value at least 1.6-fold (0.22 log units) from the limit.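

In this assay the change gives an at least 74-fold higher number from compound 1 to compound 4 (1.87 log units; beyond the scatter), and the reading for compound 4 is a limit of the assay, not a number. So a third, quite different group, a ring-free methyl ester chain with no hydrogen-bond donor, also loses the activity, and among the compounds shown only the 2-aminoethyl group of compound 1 keeps a measurable value, with none going against this. The steps from compound 2 and from compound 3 to compound 4 cannot be read, and the series gathers at one limit: the limit of > 50000 nM in this assay, at which 3 of the 4 values shown sit.

Going by these compounds, it remains open whether the amine itself matters or the chain around it, which a longer amine chain or a hydroxyethyl group on the same amide nitrogen could test. On these data alone, a carboxylic acid in place of the methyl ester is also open.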